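From compound 1 to compound 3: one chain exchanged

The source may hold more compounds than are shown below. What is called first, only, known or untested is meant among the compounds shown, and "the series" means these compounds.

Compound 1 `COc1ccc(S(=O)(=O)N(CC(N)=O)c2ccc(N(CC(N)=O)S(=O)(=O)c3ccc(SCCOCCN=C=S)cc3)c3ccccc23)cc1`: > 10000 nM
Compound 2 `COc1ccc(S(=O)(=O)N(CC(N)=O)c2ccc(N(CC(N)=O)S(=O)(=O)c3ccc([S+]([O-])CCOCCOCCOCCN=C=S)cc3)c3ccccc23)cc1`: > 10000 nM

Both compounds were tested in an ADME assay on cells (Peritoneal macrophage, Mus musculus) for cytotoxicity, read by CCK-8 assay, with a stated time of 24 h; a lower number here means that less compound is tolerated, a higher number that more compound is tolerated. Compound 1 gives > 10000 nM, which is a limit of the assay and not a number. Compound 2 gives > 10000 nM, which is likewise a limit. The measured record therefore consists only of the limit of > 10000 nM in this assay, at which 2 of the 2 values shown sit, and compound 1 has no numerical value.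

Compound 3 `COc1ccc(S(=O)(=O)N(CC(N)=O)c2ccc(N(CC(N)=O)S(=O)(=O)c3ccc(S(=O)(=O)CCCN=C=S)cc3)c3ccccc23)cc1` keeps the core of compound 1 and differs in one group, on an aromatic carbon of a six-membered aromatic ring of carbon only, para to a large group: a group of 9 heavy atoms (4 carbon, 1 nitrogen, 2 oxygen, 2 sulfur; no ring) in place of a group of 9 heavy atoms (5 carbon, 1 nitrogen, 1 oxygen, 2 sulfur; no ring), on an aromatic carbon. Among the measured compounds shown here, no measured step is available to size this change. Given the limit of compound 1 at > 10000 nM, no step beyond the scatter is expected in this assay. The expected step, a step that the limit leaves unreadable from compound 1 to compound 3, is only an estimate, and the result may again be a limit. Compound 3 is estimated at 15000 nM, within an expected range of 8000 nM to 40000 nM.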

Compound 3, half-maximal cytotoxic concentration: > 10000 nM
Compound 3 was reported as a limit (the forecaster's own chance of this, stated with the estimate: 85%); the middle value is on the limit's open side.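

In this assay compound 3 gives > 10000 nM, which is a limit of the assay and not a number. No step from compound 1 to compound 3 can therefore be read: the limit of > 10000 nM in this assay, at which 3 of the 3 values shown sit.

The compounds shown leave open where the half-maximal cytotoxic concentration of any of them lies, and whether exchanging the chain shifts it at all.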